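Adding a Cyclopropyl Ketone Side Chain to a Bare Sulfur

The source may hold more compounds than are shown below. What is called first, only, known or untested is meant among the compounds shown, and "the series" means these compounds.

Of the compounds shown here, two have so far been tested in a functional assay on HT-29 cells (Homo sapiens) for inhibition, read by MTT assay, with a stated time of 48 h; a lower number here means a stronger inhibitor, a higher number a weaker inhibitor. Compound 1 `COc1ccc(-n2c(SCC(=O)c3ccccc3)nnc2-c2cc(OC)c(OC)c(OC)c2)cc1` carries a substituent on its sulfur. In this assay compound 1 gives only a limit of the assay, > 60000 nM. Compound 2 `COc1cc(-c2nnc(S)n2-c2ccc(N(C)C)cc2)cc(OC)c1OC` has a bare sulfanyl group and differs from compound 1 elsewhere as well. In this assay compound 2 also gives only a limit, > 60000 nM. Compound 2 thus stands at the limit of > 60000 nM in this assay, at which 2 of the 2 values shown sit; no number has been obtained for either compound.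

Compound 3 `COc1cc(-c2nnc(SCC(=O)C3CC3)n2-c2ccc(N(C)C)cc2)cc(OC)c1OC` is derived from compound 2 by one change: (cyclopropylcarbonyl)methyl in place of hydrogen on a sulfur. For the measured compounds named here, no measured pair of compounds shows this change, so its effect in this assay cannot be read from the data. Going by the values given here, the only related comparison is compound 1, which carries a different group on the same sulfur and sits at its limit, > 60000 nM.

For compound 3 the expected step of a number no higher from compound 2 to compound 3 (the limit leaves the size open) is none beyond the scatter. The estimate for compound 3 in this assay is 60000 nM, with a range from 20000 nM to 150000 nM, and most likely again only a limit.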

Compound 3, half-maximal inhibitory concentration: > 60000 nM
Compound 3 gave a limit, no number; the forecaster's own chance of this, stated with the estimate: 75%; the middle value lies on the limit itself.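

Compound 3, like compound 2, gives only a limit in this assay and not a number, so no step can be read between these two compounds: the limit of > 60000 nM in this assay, at which 3 of the 3 values shown sit.

The compounds shown leave open whether (cyclopropylcarbonyl)methyl on the sulfur changes inhibition at all, and whether any compound of this kind would give a measurable number in this assay.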